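Furan to thiophene swap on the thiosemicarbazone

This account rests on a few compounds, and the source may have more. Where it says the series, first, only, none or still open, it means among the compounds named here.

The parent hydrazinecarbothioamide, compound 1 `CC1=CC[C@H](C(C)(C)NC(=S)NN)CC1`, in a functional assay on OVCAR-3 cells (Homo sapiens) for inhibition, read by sulforhodamine B assay, with a stated time of 48 h (a lower number here means a stronger inhibitor of growth, a higher number a weaker inhibitor of growth), gives 41900 nM. Condensation of the terminal nitrogen with a furan aldehyde yields compound 2 `CC1=CC[C@H](C(C)(C)NC(=S)N/N=C/c2ccco2)CC1`, which in this assay gives 10800 nM. For the measured compounds named here, the single measured step, a 3.9-fold lower number from compound 1 to compound 2 (0.59 log units; beyond the scatter), is the only comparison so far. Compound 2 therefore stands at the lowest of the two numbers; its nearest neighbour is compound 1, whose number is higher by a margin beyond the scatter.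

Compound 3 `CC1=CC[C@H](C(C)(C)NC(=S)N/N=C/c2cccs2)CC1` keeps the whole of compound 2 except for one exchange: thiophen-2-yl in place of furan-2-yl on a carbon with a double bond to nitrogen. Going by the values given here, no measured step addresses this kind of exchange; the step from compound 1 to compound 2 concerns the introduction of the arylidene unit as a whole, not the identity of the heteroatom in the ring. With nothing in the series to suggest otherwise, no step beyond the scatter is anticipated in this assay in either direction.

Compound 3 is expected to give about 10000 nM, with a range of 4000 nM to 25000 nM. This estimate amounts to an expected step of a 1.1-fold lower number from compound 2 to compound 3 (0.03 log units; within the scatter), within the scatter.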

Compound 3, concentration for 50% growth inhibition: 13100 nM
The estimate for compound 3 lay 1.3-fold (0.12 log units) below the measured number; measured number inside the range.
By their numbers in this assay, from the lowest: compounds 2 and 3 (each within the scatter of the next); then compound 1.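

In this assay, thiophen-2-yl in place of furan-2-yl on a carbon with a double bond to nitrogen gives a 1.2-fold higher number from compound 2 to compound 3 (0.08 log units; within the scatter), so this position tolerates the exchange of the ring oxygen for sulfur without a change that can be told from the scatter. The advantage over the parent is also not confined to furan-2-yl: a 3.2-fold lower number from compound 1 to compound 3 (0.50 log units; beyond the scatter) shows that a thiophen-2-yl group on the same carbon also gives a step beyond the scatter. The data offer no explanation for why the two rings give numbers within the scatter of each other.

The compounds shown leave open whether a five-membered aromatic ring with a hetero atom is needed at all, since a phenyl ring, a pyridin-2-yl ring or a plain methyl group on that carbon could separate the contribution of the ring from that of the condensed hydrazone unit itself. Also open, as far as these compounds go, is whether a methyl or chloro group on the thiophene ring would move the number beyond the scatter from the values of compound 2 and compound 3.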